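Adding a Second Benzoyl Group to a Compound with a Low Number

The source may hold more compounds than are shown below. What is called first, only, known or untested is meant among the compounds shown, and "the series" means these compounds.

Compound 1 `COC(=O)c1ccc2ccc(C(=O)c3ccccc3)c-2cc1` carries a methoxycarbonyl group on the shared core. In an assay on cells for displacement of a labelled ligand from Orexin/Hypocretin receptor type 1 (Homo sapiens), read by scintillation counting, with stated times of 10 min and 90 min, tested at 10 uM (a higher number here means more inhibition at the concentration tested (going by the name of the read-out), a lower number less inhibition), compound 1 gives 7.2%, a small number at the concentration tested. Compound 2 `COC(=O)c1ccc2c(C(=O)c3ccccc3)cc(C(=O)c3ccccc3)c-2cc1` differs from it by benzoyl in place of hydrogen on an aromatic carbon. Measured in this assay, compound 2 gives -10.6%, so that the step of a number 17.8 percentage points lower from compound 1 to compound 2 (beyond the scatter). Compound 3 `COC(=O)Cc1ccc2ccc(C(=O)c3ccccc3)c-2cc1` sits on a different core, differing from compound 1 by (methoxycarbonyl)methyl in place of methoxycarbonyl on an aromatic carbon. In this assay compound 3 gives -37.7%, the lowest of the three numbers, and the step of a number 44.9 percentage points lower from compound 1 to compound 3 (beyond the scatter).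

Compound 4 `COC(=O)Cc1ccc2c(C(=O)c3ccccc3)cc(C(=O)c3ccccc3)c-2cc1` has not yet been measured. For the measured compounds named here, it differs from compound 3 by benzoyl in place of hydrogen on an aromatic carbon, the same change as the one from compound 1 to compound 2, made at a place described in the same words. If the change repeats what it did before, the number for compound 4 is expected to lie somewhat below that of compound 3, the expected step being a number 7.3 percentage points lower from compound 3 to compound 4 (within the scatter). This expectation rests on the step of a number 17.8 percentage points lower from compound 1 to compound 2 (beyond the scatter) seen on the other core, a single example, so it is held loosely. Compound 4 is therefore estimated at -45% in this assay, expected to fall between -75% and -15%.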

Compound 4, a percentage reported as inhibition, at one concentration (the size of the read-out at that concentration, not a potency): -21.4%
For compound 4 the middle estimate is 23.6 percentage points below the measured one; low and high end bracket the measured number.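

Adding the benzoyl group to compound 3 does not repeat what it did on the other core: in this assay it gives a number 16.3 percentage points higher from compound 3 to compound 4 (beyond the scatter), the opposite direction to the earlier step, and the two steps clearly differ: the same change on two cores in this assay, a number 17.8 percentage points lower (beyond the scatter) from compound 1 to compound 2 and a number 16.3 percentage points higher (beyond the scatter) from compound 3 to compound 4, 34.1 percentage points apart, beyond the scatter of two such steps

The other change, (methoxycarbonyl)methyl in place of methoxycarbonyl, keeps its direction but shrinks once the second benzoyl group is present, giving a number 10.8 percentage points lower from compound 2 to compound 4 (beyond the scatter), and this too stands apart from the earlier step: the same change on two cores in this assay, a number 44.9 percentage points lower (beyond the scatter) from compound 1 to compound 3 and a number 10.8 percentage points lower (beyond the scatter) from compound 2 to compound 4, 34.1 percentage points apart, beyond the scatter of two such steps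

So in this series, what either change does depends on what else the compound carries, and a step seen on one core cannot simply be carried over to another, although this rests on just four compounds at a single concentration and says nothing about why the steps differ.

The compounds shown leave open whether this dependence also holds for other groups, such as an amine at the aromatic carbon that takes the benzoyl group, or a carboxylic acid in place of methoxycarbonyl. They also leave open whether any relative of these compounds shows substantial inhibition in this assay, where even compound 1 gives only 7.2%.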